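From 1-hydroxy-1-methylethyl to ethoxy: compound 3 awaited

This account rests on a few compounds, and the source may have more. Where it says the series, first, only, none or still open, it means among the compounds named here.

Compound 1 `CC(=O)N[C@@H](C)/C=C/c1ccc(Oc2ccc3nc(C)sc3c2Cl)nc1`: 87%
Compound 2 `CC(=O)N[C@@H](C)/C=C/c1ccc(Oc2ccc3nc(C(C)(C)O)sc3c2Cl)nc1`: 92%

In an ADME assay on microsomes from liver (Homo sapiens) for metabolic stability, with a stated time of 30 min (on this read-out higher numbers stand for a more stable compound and lower numbers for a less stable compound), compound 2 gives 92%, and this lies within the scatter of compound 1 at 87%, so the two cannot be told apart. Compound 3 `CCOc1nc2ccc(Oc3ccc(/C=C/[C@H](C)NC(C)=O)cn3)c(Cl)c2s1` has not yet been measured. It differs from compound 2 at a single place, with ethoxy in place of 1-hydroxy-1-methylethyl on an aromatic carbon. Among the measured compounds shown here, only one measured step touches that same place, namely a number 5 percentage points higher from compound 1 to compound 2 (within the scatter). For the measured compounds named here, it bears on the question only indirectly, as no measured compound carries ethoxy. With that single step as the guide, no change beyond the scatter is expected in this assay, though a slight downward lean is allowed for, and the expected step is a number 6 percentage points lower from compound 2 to compound 3 (within the scatter). For compound 3 the estimated value is 86%, with an expected range of 72% to 96%.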

Compound 3, percent of the compound remaining: 91%
Beside the measured number, compound 3's estimate is 5 percentage points below it; measured number inside the range.
By their numbers in this assay, from the lowest: compounds 1, 3 and 2 (each within the scatter of the next).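

In this assay, ethoxy in place of 1-hydroxy-1-methylethyl gives a number 1 percentage points lower from compound 2 to compound 3 (within the scatter), and ethoxy in place of methyl gives a number 4 percentage points higher from compound 1 to compound 3 (within the scatter), so methyl, 1-hydroxy-1-methylethyl and ethoxy cannot be told apart at this aromatic carbon, next to the ring nitrogen and next to the ring sulfur. The change also shows that going from 1 hydrogen-bond donor in the leaving group to 0 in the entering group leaves no step beyond the scatter on this read-out, and that an oxygen-linked chain fits the same picture as the two carbon-linked groups. Nothing measured here accounts for this flat result.

Going by these compounds, whether an amine, a carboxylic acid or a longer chain such as butoxy at this place would stay level with these three remains open. So does whether a change elsewhere on the shared core would move the number.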